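Trifluoromethylphenyl replaces methylaminopyridinyl on a shared pyrazole core

The source may hold more compounds than are shown below. What is called first, only, known or untested is meant among the compounds shown, and "the series" means these compounds.

Three compounds share one core and differ only in the aryl group on it. Compound 1 `Cc1nn(-c2nc(-c3ccc(Cl)c(Cl)c3)c(SC(C)C)s2)c(C(=O)O)c1-c1cnn(C)c1` gives 6800 nM in a functional assay on BJAB cells (Homo sapiens) for antiproliferative activity, with a stated time of 4 days; a higher number here means that more compound is needed for the effect, a lower number that less compound is needed. Compound 2 `Cc1nn(-c2nc(-c3ccc(Cl)c(Cl)c3)c(SC(C)C)s2)c(C(=O)O)c1-c1ccccc1[N+](=O)[O-]` gives 4700 nM, and compound 3 `CNc1cc(-c2c(C)nn(-c3nc(-c4ccc(Cl)c(Cl)c4)c(SC(C)C)s3)c2C(=O)O)ccn1` gives 18000 nM. Compound 3 stands with the highest number of the three: the step of a 2.6-fold higher number from compound 1 to compound 3 (0.42 log units; beyond the scatter) and the step of a 3.8-fold higher number from compound 2 to compound 3 (0.58 log units; beyond the scatter) both lie beyond the scatter, while the step of a 1.4-fold lower number from compound 1 to compound 2 (0.16 log units; within the scatter) does not.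

Compound 4 `Cc1nn(-c2nc(-c3ccc(Cl)c(Cl)c3)c(SC(C)C)s2)c(C(=O)O)c1-c1ccccc1C(F)(F)F` is not yet measured. Its change from compound 3 is 2-(trifluoromethyl)phenyl in place of 2-(methylamino)pyridin-4-yl on an aromatic carbon. The step that bears most directly on it is a 3.8-fold higher number from compound 2 to compound 3 (0.58 log units; beyond the scatter), since there too a phenyl carrying a group at the 2-position stands against the 2-(methylamino)pyridin-4-yl group; the step of a 2.6-fold higher number from compound 1 to compound 3 (0.42 log units; beyond the scatter) points the same way. Compound 4 is therefore expected to show a modest lower number, roughly a 3.6-fold lower number from compound 3 to compound 4 (0.56 log units; beyond the scatter). The estimate for compound 4 is 5000 nM, within a range from 2000 nM to 12000 nM.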

Compound 4, half-maximal effective concentration: 5200 nM
The estimate for compound 4 lay 1.0-fold (0.02 log units) below the measured number; the range from low to high includes it.
By their numbers in this assay, from the lowest: compounds 2, 4 and 1 (each within the scatter of the next); then compound 3.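

At this aromatic carbon, next to the ring atom that bears a carboxy group, this assay now records a 3.5-fold lower number from compound 3 to compound 4 (0.54 log units; beyond the scatter), so a third group stands apart from 2-(methylamino)pyridin-4-yl. Trifluoromethyl and nitro on the phenyl ring are not told apart, with a 1.1-fold higher number from compound 2 to compound 4 (0.04 log units; within the scatter), and the comparison with the pyrazolyl group, a 1.3-fold lower number from compound 1 to compound 4 (0.12 log units; within the scatter), also stays within the scatter. Compound 1, compound 2 and compound 4 thus sit together despite their different groups, and only compound 3 lies beyond the scatter from each of them.

From the compounds shown here alone, the change removes the ring nitrogen and the methylamino group together, so it remains open which of them goes with the higher number of compound 3; a plain phenyl, or a pyridin-4-yl carrying an unmethylated amine, would bear on that. Nothing given here offers a reason for the gap.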